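The source may hold more compounds than are shown below. What is called first, only, known or untested is meant among the compounds shown, and "the series" means these compounds.

In a functional assay on PC-3 cells (Homo sapiens) for antiproliferative activity, read by MTT assay, with a stated time of 24 h (on this read-out higher numbers stand for weaker inhibition and lower numbers for stronger inhibition), compound 3 (`CCn1c(C(=O)N[C@@H](C)CO)ccc1C(CC)(CC)c1ccc(OCS(=O)(=O)c2ccccc2)c(C)c1`) gives 9520 nM, and compound 2 (`CCN(CC)CCNC(=O)c1ccc(C(CC)(CC)c2ccc(OCS(=O)(=O)c3ccccc3)c(C)c2)n1CC`) gives 7130 nM. These two values lie within the scatter of each other. Compound 1 (`CCn1c(C(=O)NCCNC(=O)OC(C)(C)C)ccc1C(CC)(CC)c1ccc(OCS(=O)(=O)c2ccccc2)c(C)c1`) reads > 50000 nM, which is a limit of the assay and not a number.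

The next compound to be tested is compound 4 (`CCn1c(C(=O)N[C@@H](CO)C(C)C)ccc1C(CC)(CC)c1ccc(OCS(=O)(=O)c2ccccc2)c(C)c1`), which carries 1-(hydroxymethyl)-2-methylpropyl in place of 1-(hydroxymethyl)ethyl on an amide-type nitrogen. All three measured steps involve substituents at this same nitrogen. The closest guide is a 1.3-fold higher number from compound 2 to compound 3 (0.13 log units; within the scatter), where a full exchange of the amide substituent left the read-out within the scatter. The two other steps are larger: an at least 7.0-fold lower number from compound 1 to compound 2 (0.84 log units; beyond the scatter) and an at least 5.2-fold lower number from compound 1 to compound 3 (0.72 log units; beyond the scatter). Both start from the (tert-butoxycarbonyl)amino compound, and they show that a change at this place can reach beyond the scatter.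

The change in compound 4 is smaller than any of these exchanges and keeps the hydroxymethyl group, so no clear shift is expected in this assay. The expected result is a 1.1-fold lower number from compound 3 to compound 4 (0.02 log units; within the scatter), with no size beyond the scatter. Allowing for the larger steps, compound 4 is estimated at 9000 nM. The expected range for compound 4 runs from 3500 nM to 30000 nM.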

Compound 4, half-maximal inhibitory concentration: 10600 nM
The estimate for compound 4 lay 1.2-fold (0.07 log units) below the measured number, and the stated range covers the measured number.
By their numbers in this assay, from the lowest: compounds 2, 3 and 4 (each within the scatter of the next). At a limit, above all of these: compound 1.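

In this assay, 1-(hydroxymethyl)-2-methylpropyl in place of 1-(hydroxymethyl)ethyl on the amide-type nitrogen gives no shift beyond the scatter (a 1.1-fold higher number from compound 3 to compound 4 (0.05 log units; within the scatter)), so this position tolerates the larger of these two hydroxymethyl-bearing groups in this read-out. Compound 4 also stays within the scatter of the diethylamino compound (a 1.5-fold higher number from compound 2 to compound 4 (0.17 log units; within the scatter)), which means that three different substituents at this nitrogen, those of compounds 2, 3 and 4, now give readings that cannot be told apart. Compound 1 goes against this pattern (an at least 4.7-fold lower number from compound 1 to compound 4 (0.67 log units; beyond the scatter)), but the size of that step is open-ended, as it starts from a limit of the assay and not from a number: the limit of > 50000 nM in this assay, at which 1 of the 4 values shown sits.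

The compounds shown leave open whether a carboxylic acid or a primary amine in place of the hydroxymethyl group, or a phenyl group on the same chain carbon, would carry the read-out beyond the scatter. They also leave open what sets the (tert-butoxycarbonyl)amino chain of compound 1 apart, and whether any substituent at this nitrogen can give a much lower number than those of compounds 2, 3 and 4.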